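This account rests on a few compounds, and the source may have more. Where it says the series, first, only, none or still open, it means among the compounds named here.

Measured in a functional assay on MGC-803 cells (Homo sapiens) for antiproliferative activity, read by CCK-8 assay, with a stated time of 72 h; a lower number here means a stronger inhibitor, a higher number a weaker inhibitor:
compound 1 `Nc1ccccc1NC(=O)c1ccc(COc2ccc([N+](=O)[O-])cc2)cc1`: > 32000 nM (a limit)
compound 2 `Nc1ccccc1NC(=O)c1ccc(CN2CCc3cc(Br)ccc32)cc1`: 7390 nM
compound 3 `Nc1ccccc1NC(=O)c1ccc(COc2ccc(Cl)cc2)cc1`: > 32000 nM (a limit)

Compound 3 stands at > 32000 nM, which is a limit and not a number. The next compound, compound 4 `COc1ccc(OCc2ccc(C(=O)Nc3ccccc3N)cc2)cc1`, has not yet been measured. It differs from compound 3 by methoxy in place of chloro on an aromatic carbon, para to a large group. Among the measured compounds shown here, only one measured step bears on this place: a step that the two limits leave unreadable from compound 1 to compound 3. That step has no readable size, so it offers nothing to scale from. What remains is the limit of > 32000 nM in this assay, at which 2 of the 3 values shown sit, and both compounds of that step belong to it. No step beyond the scatter is therefore expected in this assay, and compound 4 would most likely also reach the limit. The expected change is a number no higher from compound 3 to compound 4 (the limit leaves the size open). Compound 4 is estimated at 32000 nM, with an expected range from 12000 nM to 80000 nM.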

Compound 4, half-maximal inhibitory concentration: 3480 nM
Beside the measured number, compound 4's estimate is 9.2-fold (0.96 log units) above it; measured number below the stated range.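

In this assay, this place on the aromatic ring, para to a large group, proves responsive to the group it carries: methoxy in place of chloro gives an at least 9.1-fold lower number from compound 3 to compound 4 (0.96 log units; beyond the scatter). Methoxy in place of nitro at the same place gives an at least 9.1-fold lower number from compound 1 to compound 4 (0.96 log units; beyond the scatter), and both sizes are open-ended, since each step starts from a limit. The step between the chloro and nitro compounds cannot be read, so the earlier compounds showed only that both sat at one limit: the limit of > 32000 nM in this assay, at which 2 of the 4 values shown sit.

The compounds shown leave open whether this gain is particular to methoxy or would also appear with a hydroxyl, an amine or a longer ether such as ethoxy. They also leave open how far compound 1 and compound 3 actually lie from compound 4, as only limits are given for those two.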